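The source may hold more compounds than are shown below. What is called first, only, known or untested is meant among the compounds shown, and "the series" means these compounds.

Measured compounds:
- compound 1, `Cc1cc(-c2ccc(O)cc2)c2ncc(CSCCc3ccccc3)n2c1`: 20 ug/mL
- compound 2, `Cc1cc(-c2cccc(O)c2)c2ncc(CSCCc3ccccc3)n2c1`: 20 ug/mL

In an ADME assay on HEL cells (Homo sapiens) for cytotoxicity, with a stated time of 3 days (on this read-out higher numbers stand for lower toxicity in this test and lower numbers for higher toxicity in this test), compound 2 gives 20 ug/mL. Going by the values given here, it stands level with compound 1 at the digits printed; the only measured step, no change at the digits printed from compound 1 to compound 2 (within the scatter), lies within the scatter. Compound 3, `Cc1cc(-c2ccccc2)c2ncc(CSCCc3ccccc3)n2c1`, has not yet been measured. It differs from compound 2 in one place: hydrogen in place of hydroxy on an aromatic carbon. The hydroxy leaves and nothing but a hydrogen enters. Among the compounds with values here, the one step available, moving the hydroxy from one place on the ring to another, left the number unchanged, so nothing seen so far points to a change in this assay beyond the scatter when that hydroxy is taken away. The step from compound 2 to compound 3 is therefore expected to be small: no change at the digits printed from compound 2 to compound 3 (within the scatter). For compound 3 the estimated value in this assay is 20 ug/mL, with a range from 8 ug/mL to 50 ug/mL.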

Compound 3, minimum cytotoxic concentration: 20 ug/mL
Compound 3: the middle estimate sits on the measured number at the digits printed; low and high end bracket the measured number.
By their numbers in this assay, from the lowest: compounds 1, 2 and 3 (each within the scatter of the next).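

Removing the hydroxy from the aromatic ring altogether gives no change at the digits printed from compound 2 to compound 3 (within the scatter) in this assay and, starting from the other hydroxy placement, no change at the digits printed from compound 1 to compound 3 (within the scatter) as well. The earlier pair showed only that moving the hydroxy around the ring left the number in place; these steps show that, across these three compounds, the number also stays put without any hydroxy on that ring. So neither the place of this group nor its presence shifts this read-out beyond the scatter, and no measurement at hand explains why the number stays flat.

On these data alone, whether a different group on this ring would leave the number equally flat stays open: an amine, a carboxylic acid or a methoxy group could read differently from hydroxy. These three compounds also say nothing about changes to the shared core or to its sulfur-bearing side chain.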